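The compounds below may be only part of what the source reports. "The series", "measured", "known", "first", "only" and "open" are said of these compounds alone.

Measured so far:
Compound 1, `Cc1ccc2ncc(S(=O)(=O)c3ccc(F)cc3)c(N3CCC(C)CC3)c2c1`, gives 90%.
Compound 2, `Cc1ccc2ncc(S(=O)(=O)c3ccc(C)c(Cl)c3)c(N3CCC(C)CC3)c2c1`, gives 91%.
Compound 3, `Cc1ccc2ncc(S(=O)(=O)c3ccccc3)c(N3CCC(C)CC3)c2c1`, gives 67%.

In an assay on isolated protein for displacement of a labelled ligand from metabotropic glutamate receptor 5 (Homo sapiens), with a stated time of 60 min, tested at 1 uM (on this read-out higher numbers stand for more inhibition at the one concentration tested (going by the name of the read-out) and lower numbers for less inhibition), compound 3 stands lowest of the three numbers. The two steps that lead to it are both beyond the scatter: a number 23 percentage points lower from compound 1 to compound 3 (beyond the scatter) and a number 24 percentage points lower from compound 2 to compound 3 (beyond the scatter), while the step between the two substituted analogues, a number 1 percentage points higher from compound 1 to compound 2 (within the scatter), lies within the scatter. The unmeasured compound 4, `Cc1ccc2ncc(S(=O)(=O)c3ccc(F)c(Cl)c3)c(N3CCC(C)CC3)c2c1`, differs from compound 3 in one place: 3-chloro-4-fluorophenyl in place of phenyl on a sulfonyl sulfur. This change bears on the measured steps directly, since it reverses the kind of change seen from compound 1 and compound 2 to compound 3, where removing fluoro alone or replacing 3-chloro-4-methylphenyl by plain phenyl each lowered the number by a modest amount beyond the scatter. Compound 4 carries both a fluoro and a chloro on the phenyl, so an increase of about the same size is expected, bringing it back near the level of compound 1 and compound 2. Compound 4 is therefore estimated to give 89%, with a likely range from 78% to 97%. This estimate for compound 4 corresponds to an expected a number 22 percentage points higher from compound 3 to compound 4 (beyond the scatter).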

Compound 4, a percentage reported as inhibition, at one concentration (the size of the read-out at that concentration, not a potency): 93%
For compound 4 the middle estimate is 4 percentage points below the measured one; measured number inside the range.
By their numbers in this assay, from the lowest: compound 3; then compounds 1, 2 and 4 (each within the scatter of the next).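

In this assay, 3-chloro-4-fluorophenyl in place of phenyl on the sulfonyl sulfur gives a number 26 percentage points higher from compound 3 to compound 4 (beyond the scatter), so a ring carrying both chloro and fluoro also stands clear of the plain phenyl of compound 3. The further substituent cannot be told apart here: chloro in place of hydrogen on an aromatic carbon gives a number 3 percentage points higher from compound 1 to compound 4 (within the scatter), and fluoro in place of methyl on an aromatic carbon gives a number 2 percentage points higher from compound 2 to compound 4 (within the scatter), so among compounds 1, 2 and 4 neither change separates one from another, and only compound 3 stands apart. Nothing available explains why the substituted rings give higher numbers than plain phenyl.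

As far as these compounds go, with compounds 1, 2 and 4 this close at a single concentration, any order among them stays open, as does whether a phenyl carrying chloro as its only substituent would reach the same level. From the compounds shown here alone, it is also open how this position on the sulfonyl sulfur would respond to a methoxy, a nitrile, an amine or a carboxylic acid on the ring.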